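Defined configuration at the diol centre of compound 2

This account rests on a few compounds, and the source may have more. Where it says the series, first, only, none or still open, it means among the compounds named here.

Compound 2 `O=C1c2c[n+]([O-])c3ccccc3c2C(=O)c2c1c1ccccc1n2Cc1cn(CC(O)CO)nn1` gives 1110 nM in a functional assay on MCF7 cells (Homo sapiens) for cytotoxicity, read by MTT assay, with a stated time of 72 h; on this read-out lower numbers stand for stronger inhibition and higher numbers for weaker inhibition. Of the three measured compounds it stands second highest: compound 1 `CN(C)CCCCCn1c2c(c3ccccc31)C(=O)c1c[n+]([O-])c3ccccc3c1C2=O` gives 200 nM, and the step of a 5.6-fold higher number from compound 1 to compound 2 (0.74 log units; beyond the scatter) lies beyond the scatter, while compound 3 `CCCN1CCN(CCCCn2c3c(c4ccccc42)C(=O)c2c[n+]([O-])c4ccccc4c2C3=O)CC1` gives 1280 nM, and the step of a 1.2-fold higher number from compound 2 to compound 3 (0.06 log units; within the scatter) lies within it. Compound 4 `O=C1c2c[n+]([O-])c3ccccc3c2C(=O)c2c1c1ccccc1n2Cc1cn(C[C@@H](O)CO)nn1` differs from compound 2 only in that (the two compounds have the same atoms and bonds; at least one stereo element is drawn with a configuration in one of them and without one in the other: 1 of 1 stereo elements differ; a stereocentre at a saturated chain carbon is drawn without a configuration in compound 2 and R in compound 4). Within the data shown here, no measured step bears on a change of drawn configuration alone; both a 5.6-fold higher number from compound 1 to compound 2 (0.74 log units; beyond the scatter) and a 6.4-fold higher number from compound 1 to compound 3 (0.81 log units; beyond the scatter) involve exchange of groups. With atoms and bonds unchanged, no step beyond the scatter is expected, and a 1.0-fold lower number from compound 2 to compound 4 (0.00 log units; within the scatter) is the expected outcome. Compound 4 is therefore estimated at 1100 nM in this assay, with an expected range of 500 nM to 2500 nM.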

Compound 4, half-maximal inhibitory concentration: 600 nM
The estimate for compound 4 lay 1.8-fold (0.26 log units) above the measured number; low and high end bracket the measured number.
By their numbers in this assay, from the lowest: compound 1; then compounds 4, 2 and 3 (each within the scatter of the next, the first and the last beyond it).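

In this assay, a defined R configuration at the diol centre gives a result within the scatter (a 1.9-fold lower number from compound 2 to compound 4 (0.27 log units; within the scatter)), so this change alone shows no separable effect at this position. The only recorded difference in this pair is this: the fact that one of compounds 2 and 4 is drawn with a defined configuration and the other without, at the place where they differ. With that centre defined, the 1-(2,3-dihydroxypropyl)-1H-1,2,3-triazol-4-yl compound separates from the propylpiperazine compound (a 2.1-fold lower number from compound 3 to compound 4 (0.33 log units; beyond the scatter)) but still trails the dimethylamino compound (a 3.0-fold higher number from compound 1 to compound 4 (0.48 log units; beyond the scatter)).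

Open, as far as these compounds go, is how the S configuration at this centre would read. Also open, from the compounds shown here alone, is whether a carboxylic acid in place of the diol would hold the number of compound 4.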